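Moving the benzyl substituent and the expected cytotoxicity gain

A few compounds are considered here, and "the series" means these few. Any claim that something is new, unique, unknown or untested is made for them only; others in the source may bear on it.

Compound 1 `Cc1cc(S(=O)(=O)/N=C(\N)n2nccc2-c2ccccc2)c(SCc2ccccc2Cl)cc1Cl` gives 19000 nM in a functional assay on HeLa cells (Homo sapiens) for cytotoxicity, read by MTT assay, with a stated time of 72 h (a lower number here means a stronger inhibitor, a higher number a weaker inhibitor), the highest of the three numbers recorded. Compound 2 `Cc1cccc(CSc2cc(Cl)c(C)cc2S(=O)(=O)/N=C(\N)n2nccc2-c2ccccc2)c1` gives 8000 nM and compound 3 `Cc1cc(-c2ccccc2)n(/C(N)=N/S(=O)(=O)c2cc(C)c(Cl)cc2SCc2cccc(Cl)c2)n1` gives 8000 nM; each stands a step away from compound 1 by the same margin. Compound 4 `Cc1ccc(CSc2cc(Cl)c(C)cc2S(=O)(=O)/N=C(\N)n2nccc2-c2ccccc2)cc1` differs from compound 1 as follows: 4-methylphenyl in place of 2-chlorophenyl on a saturated chain carbon bound to a sulfur. Among the compounds with values here, the one measured step that bears on this change is a 2.4-fold lower number from compound 1 to compound 2 (0.38 log units; beyond the scatter), which swaps the same 2-chlorophenyl for a methylphenyl. The author therefore expects a step of similar modest size and the same direction, a 2.4-fold lower number from compound 1 to compound 4 (0.38 log units; beyond the scatter). Compound 4 is accordingly estimated at 8000 nM, within a range from 3000 nM to 22000 nM.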

Compound 4, half-maximal inhibitory concentration: 17000 nM
Compound 4: the middle estimate sits 2.1-fold (0.33 log units) below what was measured, within the range that was stated.
By their numbers in this assay, from the lowest: compounds 2 and 3 (each within the scatter of the next); then compounds 4 and 1 (each within the scatter of the next).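

In this assay the swap of 2-chlorophenyl for 4-methylphenyl gives a 1.1-fold lower number from compound 1 to compound 4 (0.05 log units; within the scatter) and so shows no measurable change, whereas 4-methylphenyl in place of 3-methylphenyl gives a 2.1-fold higher number from compound 2 to compound 4 (0.33 log units; beyond the scatter) at this same place. The methylphenyl step seen earlier therefore does not hold for every methylphenyl on the saturated chain carbon bound to a sulfur, since the two methylphenyl groups read differently here. No measurement at hand explains this difference. The compounds shown leave open how an amine or a carboxylic acid in place of the methyl of 4-methylphenyl would read.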